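The compounds below may be only part of what the source reports. "The series", "measured", "known", "first", "only" and "open" are said of these compounds alone.

Measured so far in a physicochemical assay for solubility, read by mass spectrometry, in phosphate buffer, with a stated time of 24 h, at pH 7.4; a lower number here means a less soluble compound, a higher number a more soluble compound:
- compound 1 `CC[C@H](C)C(=O)N1CCC(CC(=O)Nc2ccc(OC(F)(F)F)c(F)c2)CC1` gives 21 ug/mL
- compound 2 `O=C(Nc1ccc(C(F)(F)F)cc1)NC1CCN(C(=O)[C@@H]2CCOC2)CC1` gives 1.4 ug/mL
- compound 3 `O=C(Nc1ccc(OC(F)(F)F)cc1)NC1CCN(C(=O)C2CCOC2)CC1` gives 29 ug/mL

Compound 3 (29 ug/mL) stands level, within the scatter, with compound 1 (21 ug/mL). Compound 2 (1.4 ug/mL) lies lower than compound 3, well beyond the scatter.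

Compound 4 `O=C(Nc1ccc(OC(F)(F)F)cc1)NC1CCN(C(=O)c2cc[nH]c2)CC1` carries 1H-pyrrol-3-yl in place of oxolan-3-yl on a carbonyl carbon. Among the measured compounds shown here, no measured pair shows this change, so the expectation is a judgement and remains uncertain. A fall beyond the scatter is expected in this assay, with the estimated step of a 2.9-fold lower number from compound 3 to compound 4 (0.46 log units; beyond the scatter) as its size. Compound 4 is estimated at 10 ug/mL (expected range 3 ug/mL to 30 ug/mL).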

Compound 4, solubility: 43 ug/mL
The estimate for compound 4 lay 4.3-fold (0.63 log units) below the measured number, outside the stated range (above it).
By their numbers in this assay, from the lowest: compound 2; then compounds 1, 3 and 4 (each within the scatter of the next, the first and the last beyond it).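

On a carbonyl carbon, 1H-pyrrol-3-yl in place of oxolan-3-yl gives a 1.5-fold higher number from compound 3 to compound 4 (0.17 log units; within the scatter) in this assay, so swapping this non-aromatic ring for an aromatic one of the same size, with a hydrogen-bond donor in place of an acceptor, moves the reading no further than the scatter. The earlier compounds shown here held no pair differing at this position alone. No measurement here explains why the two groups read level. Still open, on these data alone, is whether 1-methyl-1H-pyrrol-3-yl, which lacks the ring hydrogen on nitrogen, would read level as well. An amine or a carboxylic acid at this position also remains untested in the compounds shown.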